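Amide aryl substituent swaps on a shared flavonol-type core

This account rests on a few compounds, and the source may have more. Where it says the series, first, only, none or still open, it means among the compounds named here.

Measured compounds:
- compound 1, `COc1ccccc1C(=O)Nc1cccc(-c2oc3cc(-c4ccc(F)cc4)ccc3c(=O)c2O)c1`: 5110 nM
- compound 2, `Cc1ccccc1C(=O)Nc1cccc(-c2oc3cc(-c4ccc(F)cc4)ccc3c(=O)c2O)c1`: 4910 nM
- compound 3, `COc1cccc(C(=O)Nc2cccc(-c3oc4cc(-c5ccc(F)cc5)ccc4c(=O)c3O)c2)c1`: 9160 nM

All three were tested in a functional assay on MDA-MB-231 cells (Homo sapiens) for antiproliferative activity, read by CCK-8 assay, with a stated time of 72 h; a lower number here means a stronger inhibitor, a higher number a weaker inhibitor. Compound 1 and compound 2 differ only by methyl in place of methoxy on an aromatic carbon; the step of a 1.0-fold lower number from compound 1 to compound 2 (0.02 log units; within the scatter) is as small as a step can be, and the two numbers cannot be told apart. Compound 3 carries the same kind of amide but with a different arrangement, described by 3-methoxyphenyl in place of 2-methoxyphenyl on a carbonyl carbon; the step of a 1.8-fold higher number from compound 1 to compound 3 (0.25 log units; within the scatter) and likewise a 1.9-fold higher number from compound 2 to compound 3 (0.27 log units; within the scatter) both stay inside the scatter, so no order among the three is established.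

Compound 4, `Cc1cccc(C(=O)Nc2cccc(-c3oc4cc(-c5ccc(F)cc5)ccc4c(=O)c3O)c2)c1`, has not been measured. It stands to compound 3 as compound 2 stands to compound 1: the change is methyl in place of methoxy on an aromatic carbon. It is the same kind of change as that from compound 1 to compound 2, not the same change. The place differs: in compound 1 the group sits ortho to a large group, in compound 3 it sits meta to a large group. The earlier instance, a 1.0-fold lower number from compound 1 to compound 2 (0.02 log units; within the scatter), gave no movement at all. Compound 3 gives 9160 nM. The expectation for compound 4 is a step of about a 1.0-fold lower number from compound 3 to compound 4 (0.01 log units; within the scatter) in this assay, resting on that single precedent and on that value of compound 3. With one precedent only, the range is kept wide. Compound 4 is estimated at 9000 nM, between 4500 nM and 18000 nM.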

Compound 4, half-maximal inhibitory concentration: 2840 nM
Estimate against measurement, compound 4: 3.2-fold (0.50 log units) above, outside the stated range (below it).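

In this assay, methyl in place of methoxy did not carry over unchanged from one amide to the other, with the step on the 3-methoxyphenyl amide being a 3.2-fold lower number from compound 3 to compound 4 (0.51 log units; beyond the scatter), and the two instances of the swap differ: the same change on two cores in this assay, a 1.0-fold lower number (0.02 log units; within the scatter) from compound 1 to compound 2 and a 3.2-fold lower number (0.51 log units; beyond the scatter) from compound 3 to compound 4, 3.1-fold (0.49 log units) apart, beyond the scatter of two such steps. This shows that the step seen on the 2-methoxyphenyl amide cannot be taken as a guide for the 3-methoxyphenyl amide, but two pairs give no general rule for the swap, and they do not show what lies behind the difference. Compound 4 also does not separate from the other two amides, with a 1.7-fold lower number from compound 2 to compound 4 (0.24 log units; within the scatter) and a 1.8-fold lower number from compound 1 to compound 4 (0.26 log units; within the scatter), so the 3-methylphenyl amide is not established as better than either, and only compound 3 stands apart from it.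

The compounds shown leave open whether the difference between the two pairs extends to other groups on this amide ring, such as a chlorine atom, an amine or a carboxylic acid in place of the methyl of the 3-methylphenyl group. They also leave open whether the step from 3-methoxyphenyl to 3-methylphenyl holds in any other cell line or on a different core.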